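The source may report more compounds than this note shows. Statements on the series, on what has been measured and on what is new or still open speak of the compounds shown alone.

In an ADME assay on microsomes from liver (Homo sapiens) for metabolic stability, read by LC-MS, using NADPH, with a stated time of 30 min, tested at 1 uM (a lower number here means slower removal, a higher number faster removal of the compound), three compounds have been measured so far. Compound 1 `CC#Cc1cncc(-c2ccc3c(c2)[C@@]2(COC(N)=N2)c2cc(Cl)ncc2O3)c1` gives 27 mL.min-1.g-1. Compound 2 `COc1cc2c(cn1)Oc1ccc(NC(=O)c3ccc(Cl)cn3)cc1[C@@]21COC(N)=N1` reaches only the limit of < 14 mL.min-1.g-1, so no number is known for it. Compound 3 `CC#Cc1cncc(-c2ccc3c(c2)[C@@]2(COC(N)=N2)c2cc(C4=CCCOC4)ncc2O3)c1` gives 76 mL.min-1.g-1, the highest of the two numbers, with compound 1 standing nearest. The step of a 2.8-fold higher number from compound 1 to compound 3 (0.45 log units; beyond the scatter) came with a group of 6 heavy atoms (5 carbon, 1 oxygen; one six-membered non-aromatic ring with 1 hetero atom) in place of one chlorine atom, on an aromatic carbon.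

Compound 4 `CC#Cc1cncc(-c2ccc3c(c2)[C@@]2(COC(N)=N2)c2cc(-c4ccnc(F)c4)ncc2O3)c1` differs from compound 3 by a group of 7 heavy atoms (5 carbon, 1 nitrogen, 1 fluorine; one six-membered aromatic ring with 1 hetero atom) in place of a group of 6 heavy atoms (5 carbon, 1 oxygen; one six-membered non-aromatic ring with 1 hetero atom), on an aromatic carbon. Within the data shown here, no measured step exchanges one ring for another at this position, so only the size of a 2.8-fold higher number from compound 1 to compound 3 (0.45 log units; beyond the scatter) shows how far the number can move there. A modest shift in either direction is therefore open. Compound 4 is expected to give 45 mL.min-1.g-1, between 15 mL.min-1.g-1 and 120 mL.min-1.g-1, which would mean a 1.7-fold lower number from compound 3 to compound 4 (0.23 log units; within the scatter).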

Compound 4, intrinsic clearance in microsomes: 40 mL.min-1.g-1
Compound 4: the middle estimate sits 1.1-fold (0.05 log units) above what was measured; measured number inside the range.
By their numbers in this assay, from the lowest: compounds 1, 4 and 3 (each within the scatter of the next, the first and the last beyond it). At a limit, below all of these: compound 2.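

With 2-fluoropyridin-4-yl in place of the non-aromatic ring, the result is a 1.9-fold lower number from compound 3 to compound 4 (0.28 log units; within the scatter) and with it in place of chloro the result is a 1.5-fold higher number from compound 1 to compound 4 (0.17 log units; within the scatter). This position therefore also accepts an aromatic ring, and the number stays within the scatter of both earlier groups, even though those two groups lie beyond the scatter of each other. Nothing shown here explains these numbers.

What the fluorine contributes stays open, since an unsubstituted pyridin-4-yl group is not among the compounds shown. As far as these compounds go, whether an amine or a carboxylic acid at this carbon would move the number further also stays open.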